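The source may hold more compounds than are shown below. What is called first, only, known or untested is meant among the compounds shown, and "the series" means these compounds.

Working notes on a small series built on a shared core, followed in a functional assay on a cell-free system (Platelet, plasma, Homo sapiens) for inhibition, with stated times of 1 min and 3 min; a lower number here means a stronger inhibitor, a higher number a weaker inhibitor. Going by the values given here, only one compound has a number so far: compound 2 (`CCCSc1nc(NC2CCCCC2)c2ncn([C@@H]3O[C@H](CO)[C@@H](O)[C@H]3O)c2n1`) reads 151000 nM. Compound 1 (`CCSc1nc(NCc2ccc(OC)cc2)c2ncn([C@@H]3O[C@H](CO)[C@@H](O)[C@H]3O)c2n1`) stands as "not determined" (no result reported). Compound 3 (`CCSc1nc(NCc2ccc(C)cc2)c2ncn([C@@H]3O[C@H](CO)[C@@H](O)[C@H]3O)c2n1`) also stands as "not determined" (no result reported), so it has no position on the scale, and with compound 1 it is one of two entries without a single number.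

The next compound is compound 4 (`CCSc1nc(NC2CCCCC2)c2ncn([C@@H]3O[C@H](CO)[C@@H](O)[C@H]3O)c2n1`), with cyclohexyl in place of 4-methylbenzyl on a nitrogen on an aromatic ring. The same change, cut one bond further out, reads (4-methylbenzyl)amino to cyclohexylamino.

Among the compounds with values here, no measured step sizes this change, and compound 3 offers no number to start from. The working expectation in this assay is therefore no step beyond the scatter, in either direction, though the data cannot test this. The better guide is compound 2, which also carries cyclohexyl on that nitrogen and sits at 151000 nM, so a weak inhibitor is expected here too. For compound 4 the estimated value is 150000 nM, with an expected range of 50000 nM to 450000 nM.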

Compound 4, half-maximal inhibitory concentration: 104000 nM
Beside the measured number, compound 4's estimate is 1.4-fold (0.16 log units) above it; the range from low to high includes it.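

In this assay, the series now has its first readable step, a 1.5-fold lower number from compound 2 to compound 4 (0.16 log units; within the scatter), for hydrogen in place of methyl on a saturated chain carbon, two bonds along the chain from a sulfur. With cyclohexyl held on the nitrogen, this change on the sulfur chain stays within the scatter, so the ethyl and propyl chains cannot be told apart in this pair. The step from compound 3 to compound 4, cyclohexyl in place of 4-methylbenzyl, cannot be read, as compound 3 has no number, and no measurement beyond these values bears on this result.

The compounds shown leave open whether the sulfur chain matters at all when it is extended to a butyl or pentyl chain, or when it ends in an amine or a carboxylic acid. They also leave open how the nitrogen substituent affects this assay, since a reading for a benzyl group or a smaller chain such as methyl on that nitrogen, set against compound 4, would be needed to size that position.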